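The source may hold more compounds than are shown below. What is called first, only, known or untested is meant among the compounds shown, and "the series" means these compounds.

Measured so far:
- compound 1 `CCOC(=O)c1c(C)[nH]c(=O)c(C#N)c1-c1ccc(OC)cc1` — in a functional assay on A549 cells (Homo sapiens) for inhibition, read by MTT assay, with a stated time of 24 h (a lower number here means a stronger inhibitor, a higher number a weaker inhibitor), compound 1 gives 25100 nM
- compound 2 `CCOC(=O)c1c(C)[nH]c(=O)c(C#N)c1-c1ccc([N+](=O)[O-])cc1` — in this assay compound 2 returns only a limit, > 100000 nM

Among the measured compounds shown here, the single measured step in this assay is an at least 3.9-fold higher number from compound 1 to compound 2 (0.60 log units; beyond the scatter). Because compound 2 sits at the limit of > 100000 nM in this assay, at which 1 of the 2 values shown sits, its number is not fixed, and the step from compound 1 to compound 2 is known only as a floor. Compound 2 therefore stands at the weak end of what has been seen, with nothing beyond the limit to say how far.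

Compound 3 `CCOC(=O)c1c(C)[nH]c(=O)c(C#N)c1-c1ccc(C#N)cc1` has not yet been measured in this assay. It differs from compound 2 by cyano in place of nitro on an aromatic carbon. For the measured compounds named here, no measured step carries this exact change. Going by the values given here, the only step available, an at least 3.9-fold higher number from compound 1 to compound 2 (0.60 log units; beyond the scatter), shows that swapping the methoxy for the nitro moved the number beyond the scatter, and it is the nitro that now leaves. The change is expected to bring compound 3 somewhere between compound 1 and the limit, with a real chance of another limit. Compound 3 is estimated at 60000 nM, in a range from 20000 nM to 150000 nM. That estimate corresponds to an expected step of an at least 1.6-fold lower number from compound 2 to compound 3 (0.22 log units; that floor lies within the scatter).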

Compound 3, half-maximal inhibitory concentration: > 100000 nM
Compound 3: only a limit was reported (the forecaster's own chance of this, stated with the estimate: 40%); middle value at least 1.6-fold (0.22 log units) from the limit.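

Cyano in place of methoxy on the aromatic ring gives an at least 3.9-fold higher number from compound 1 to compound 3 (0.60 log units; beyond the scatter), so the move away from compound 1 is no longer tied to the nitro group alone. Two different replacements of the methoxy at this position now end at the same ceiling in this assay: the limit of > 100000 nM in this assay, at which 2 of the 3 values shown sit. Compound 2 and compound 3 are both limits, so the step between them cannot be read and no order of nitro and cyano follows from these data. Among the three groups shown only the methoxy of compound 1 gives a measured number, 25100 nM.

Three compounds cannot show whether the measurable activity belongs to the methoxy itself or would also appear with another group at this position, such as an amine, a hydroxyl, a methyl, a chlorine or a longer alkoxy chain. Also open, going by these compounds, are how far compound 2 and compound 3 lie past the limit and whether a carboxylic acid or an amide in place of the ethyl ester would shift the numbers on the shared core.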